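The source may hold more compounds than are shown below. What is called first, only, known or untested is meant among the compounds shown, and "the series" means these compounds.

Within the data shown here, compound 2 `CC(=O)OCc1ccc(C(=O)c2ccn(-c3ccc4c(c3)B(O)OC4)c2)cc1` is the one member of this small set with a number in an ADME assay on L929 cells (Mus musculus) for cytotoxicity, read by resazurin assay, with a stated time of 72 h; a higher number here means a weaker inhibitor, a lower number a stronger inhibitor: there compound 2 gives 10 ug/mL. Compound 1 `O=C(c1ccn(-c2ccc3c(c2)B(O)OC3)c1)c1ccc(Cl)cc1Cl` is a different case. In this assay compound 1 gives > 10 ug/mL, which is a limit of the assay and not a number; the relevant note is the limit of > 10 ug/mL in this assay, at which 1 of the 2 values shown sits. Compound 3 `Nc1ccc(C(=O)c2ccn(-c3ccc4c(c3)B(O)OC4)c2)cc1` has not yet been measured. It differs from compound 2 by amino in place of acetoxymethyl on an aromatic carbon. Among the measured compounds shown here, no step between measured compounds is available here, so the size of this change has no precedent in the set. With the little that is shown, the step is expected to be small, within the usual scatter and in no firm direction, as a 1.2-fold higher number from compound 2 to compound 3 (0.08 log units; within the scatter). Compound 3 is therefore expected to give about 12 ug/mL in this assay, with a likely range of 5 ug/mL to 30 ug/mL, and a fair chance that only a limit is reported.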

Compound 3, half-maximal inhibitory concentration: 3.9 ug/mL
Compound 3: the middle estimate sits 3.1-fold (0.49 log units) above what was measured, outside the stated range (below it).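

Among these compounds, the first readable step at this position in this assay is beyond the scatter: amino in place of acetoxymethyl, on an aromatic carbon para to a large group, gives a 2.6-fold lower number from compound 2 to compound 3 (0.41 log units; beyond the scatter). The wider change, 4-aminophenyl in place of 2,4-dichlorophenyl on a carbonyl carbon, gives an at least 2.5-fold lower number from compound 1 to compound 3 (0.40 log units; beyond the scatter). Compound 1 stands only at a limit of the assay, so this second step has a lower bound and no exact size: the limit of > 10 ug/mL in this assay, at which 1 of the 3 values shown sits.

The compounds shown do not tell whether the step comes with the amino group itself or with the loss of acetoxymethyl. A hydroxymethyl, a methyl or a dimethylamino group at this place could help to separate the two.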